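Compound 1 Loses a Methoxy

The source may report more compounds than this note shows. Statements on the series, on what has been measured and on what is new or still open speak of the compounds shown alone.

For the measured compounds named here, in an ADME assay on MDCK cells (Canis lupus familiaris) for cytotoxicity, read by MTT assay, with a stated time of 72 h (on this read-out higher numbers stand for weaker inhibition and lower numbers for stronger inhibition), compound 1 (`COc1ccc(/C=C/c2cc(C)no2)cc1OC`) gives 44700 nM as the higher of the two numbers known so far. Compound 2 (`COc1ccc(/C=C/C(=O)CC(C)=O)cc1OC`) gives 9900 nM and the resulting step of a 4.5-fold lower number from compound 1 to compound 2 (0.65 log units; beyond the scatter) is modest, but it replaces the 3-methyl-1,2-oxazol-5-yl group and so offers only a loose guide. Going by the values given here, compound 3 (`COc1ccc(/C=C/c2cc(C)no2)cc1`) instead has hydrogen in place of methoxy on an aromatic carbon and no measured step covers this change, so no shift beyond the scatter is expected. The expected step of a 1.1-fold lower number from compound 1 to compound 3 (0.05 log units; within the scatter) is therefore small. Compound 3 is estimated at 40000 nM with an expected range from 18000 nM to 90000 nM in this assay for now.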

Compound 3, half-maximal inhibitory concentration: 70200 nM
Compound 3: the middle estimate sits 1.8-fold (0.24 log units) below what was measured; the measured number falls inside the stated range.
By their numbers in this assay, from the lowest: compound 2; then compounds 1 and 3 (each within the scatter of the next).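

With hydrogen in place of methoxy on an aromatic carbon, ortho to a methoxy group, this assay shows a 1.6-fold higher number from compound 1 to compound 3 (0.20 log units; within the scatter), so this one methoxy can be exchanged for hydrogen with no change beyond the scatter. Unlike the change leading to compound 2, this change keeps the 3-methyl-1,2-oxazol-5-yl group and touches only this position. No measured evidence bears on the reason for this result. From the compounds shown here alone, whether an amine or a hydroxyl group at this position would read differently remains open. So does the effect of replacing the remaining methoxy with hydrogen.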